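The source may hold more compounds than are shown below. What is called first, only, known or untested is meant among the compounds shown, and "the series" means these compounds.

In a functional assay on MDA-MB-231 cells (Homo sapiens) for antiproliferative activity, read by MTT assay, with a stated time of 72 h (a lower number here means a stronger inhibitor, a higher number a weaker inhibitor), compound 1 `CN(C)CCn1cnnc1-c1cc(Oc2ccc(NC(=O)Nc3ccc(Cl)c(C(F)(F)F)c3)cc2F)ccn1` gives 1070 nM, the lowest of the two plain numbers shown. Compound 3 `CN(C)CCn1cnnc1-c1cc(Oc2ccc(NC(=O)Nc3ccc(Cl)cc3Cl)cc2F)ccn1` gives 7960 nM in this assay. Compound 2 `CN(C)CCn1cnnc1-c1cc(Oc2ccc(NC(=O)Nc3ccccc3C(F)(F)F)cc2F)ccn1` reaches only a limit of the assay, > 50000 nM, as marked by the limit of > 50000 nM in this assay, at which 1 of the 3 values shown sits. Every measured step changes the aryl group on the amide-type nitrogen: an at least 46-fold higher number from compound 1 to compound 2 (1.66 log units; beyond the scatter), a 7.4-fold higher number from compound 1 to compound 3 (0.87 log units; beyond the scatter) and an at least 6.2-fold lower number from compound 2 to compound 3 (0.79 log units; beyond the scatter). Compound 4 `CCN(CC)CCn1cnnc1-c1cc(Oc2ccc(NC(=O)Nc3ccc(Cl)c(C(F)(F)F)c3)cc2F)ccn1` keeps that aryl group of compound 1 unchanged and differs in a different place: diethylamino in place of dimethylamino on a saturated chain carbon, two bonds along the chain from an aromatic nitrogen. Within the data shown here, no measured step touches this amine tail, so the steps on the aryl side offer no direct guide to it, and a step that stays within the scatter is expected in this assay. Compound 4 is therefore estimated at 1000 nM. Its value is expected to fall between 400 nM and 3000 nM. This means an expected step of a 1.1-fold lower number from compound 1 to compound 4 (0.03 log units; within the scatter), not beyond the scatter.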

Compound 4, half-maximal inhibitory concentration: 1540 nM
The estimate for compound 4 lay 1.5-fold (0.19 log units) below the measured number; low and high end bracket the measured number.
By their numbers in this assay, from the lowest: compounds 1 and 4 (each within the scatter of the next); then compound 3. At a limit, above all of these: compound 2.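

The amine tail now has its first measured step: with 2-(diethylamino)ethyl in place of 2-(dimethylamino)ethyl, this assay shows a 1.4-fold higher number from compound 1 to compound 4 (0.16 log units; within the scatter). So, for this one pair, enlarging the amine from 3 to 5 heavy atoms gives no change that can be told apart from repeat scatter, whereas each aryl step on the amide-type nitrogen, such as a 7.4-fold higher number from compound 1 to compound 3 (0.87 log units; beyond the scatter), lies beyond it. Nothing shown here offers a reason for this result.

As far as these compounds go, it remains open whether the tail would allow a larger change, such as a morpholine ring in place of the diethylamino group, a longer chain leading to the amine, or a carboxylic acid in place of the amine. It is also unknown whether diethylamino would behave the same way alongside the 2,4-dichlorophenyl group of compound 3.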